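A few compounds are considered here, and "the series" means these few. Any claim that something is new, unique, unknown or untested is made for them only; others in the source may bear on it.

In an ADME assay on HEK293 cells (Homo sapiens) for cytotoxicity, read by MTT assay, with a stated time of 48 h (on this read-out higher numbers stand for weaker inhibition and lower numbers for stronger inhibition), compound 1 `CN(C)CCn1c(N)c(-c2nc3ccccc3[nH]2)c2nc(C#N)c(C#N)nc21` gives 9730 nM and compound 2 `CN1CCN(CCn2c(N)c(-c3nc4ccccc4[nH]3)c3nc(C#N)c(C#N)nc32)CC1` gives 10900 nM. These two differ only in the amine at the end of the side chain, and the change, a 1.1-fold higher number from compound 1 to compound 2 (0.05 log units; within the scatter), lies within the scatter. Compound 3 `CN(C)CCn1c(N)c(-c2nc3cc(Cl)ccc3[nH]2)c2nc(C#N)c(C#N)nc21` is compound 1 with chloro in place of hydrogen on an aromatic carbon, a change seen as an at least 5.1-fold higher number from compound 1 to compound 3 (0.71 log units; beyond the scatter). Compound 3 gives > 50000 nM, which is a limit of the assay and not a number.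

Compound 4 `CCN(CC)CCCCn1c(N)c(-c2nc3cc(Cl)ccc3[nH]2)c2nc(C#N)c(C#N)nc21` keeps that chloro and changes the side chain: 2-(diethylamino)ethyl in place of dimethylamino on a saturated chain carbon, two bonds along the chain from an aromatic nitrogen. Read one bond further out, this is 2-(dimethylamino)ethyl becoming 4-(diethylamino)butyl. The chloro step therefore sets the starting point but does not bear on this change. The nearest guide is the amine swap, a 1.1-fold higher number from compound 1 to compound 2 (0.05 log units; within the scatter), although it was made without chloro and left the chain length alone. Within the data shown here, no measured step covers a longer chain. On that thin evidence, only a small change is expected, with a modest lean towards a lower number, and the expected step is an at least 1.2-fold lower number from compound 3 to compound 4 (0.09 log units; that floor lies within the scatter). For compound 4 the estimated value is 40000 nM, with an expected range from 12000 nM to 90000 nM.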

Compound 4, half-maximal inhibitory concentration: 3860 nM
The estimate for compound 4 lay 10-fold (1.02 log units) above the measured number; measured number below the stated range.
By their numbers in this assay, from the lowest: compound 4; then compounds 1 and 2 (each within the scatter of the next). At a limit, above all of these: compound 3.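

In this assay, the side chain turns out to matter a good deal in the chloro series: the change at this saturated chain carbon, two bonds along the chain from an aromatic nitrogen, gives an at least 12-fold lower number from compound 3 to compound 4 (1.11 log units; beyond the scatter). The earlier amine swap at the same place, made without chloro and with no change in chain length, gave only a 1.1-fold higher number from compound 1 to compound 2 (0.05 log units; within the scatter), so this place is not silent in the assay, and a change here can move the number well beyond the scatter. The true size of the new step remains unknown, and it can be read only as a floor, because compound 3 stands at a limit of the assay: the limit of > 50000 nM in this assay, at which 1 of the 4 values shown sits.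

The change alters both the chain length and the groups on the amine, so the compounds shown cannot separate the two; a 4-(dimethylamino)butyl side chain on the chloro compound would begin to do so. They also leave open whether 4-(diethylamino)butyl would have a similar effect without the chloro, and whether a cyclic amine such as 4-methylpiperazin-1-yl at the end of the longer chain would behave in the same way.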